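The source may hold more compounds than are shown below. What is called first, only, known or untested is meant among the compounds shown, and "the series" means these compounds.

Compound 1, `Ic1nc2ccccc2[se]1`, is known in a functional assay on HCT-116 cells (Homo sapiens) for cytotoxicity, with a stated time of 3 days (on this read-out higher numbers stand for weaker inhibition and lower numbers for stronger inhibition), only as a limit: compound 1 gives > 40000 nM, a limit rather than a number. Compound 1 therefore stands at the limit of > 40000 nM in this assay, at which 2 of the 3 values shown sit, and nothing places it more finely within the set. Compound 2, `C#Cc1nc(C(=O)OCC)cs1`, likewise returns only a limit in this assay, > 40000 nM. Going by the values given here, compound 3, `C#Cc1nc2ccccc2s1`, is the one member with a number; in this assay compound 3 gives 19600 nM. Compound 4, `C#Cc1nc2ccccc2[se]1`, has not yet been measured. The change from compound 1 to compound 4 is ethynyl in place of iodo on an aromatic carbon. Among the compounds with values here, no measured pair follows the same change, so its size is open; compound 3 carries the same ethynyl group on a related core and gives 19600 nM, which is the only anchor available. The expected step is an at least 1.8-fold lower number from compound 1 to compound 4 (0.25 log units; that floor lies within the scatter), toward stronger inhibition, though starting from a limit its size is uncertain. Compound 4 is estimated at 22000 nM, within a range of 8000 nM to 60000 nM, with a fair chance that this assay again reports only a limit.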

Compound 4, half-maximal inhibitory concentration: 25000 nM
Compound 4: the middle estimate sits 1.1-fold (0.06 log units) below what was measured; low and high end bracket the measured number.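

In this assay compound 4 returns a number at this position, next to the ring nitrogen and next to the ring selenium, where compound 1 gave only a limit. Ethynyl in place of iodo gives an at least 1.6-fold lower number from compound 1 to compound 4 (0.20 log units; that floor lies within the scatter), so this change can be read only as a floor and not as a measured size. With ethynyl on both cores, compound 3 gives 19600 nM and compound 4 gives 25000 nM, two values that do not separate the cores.

From the compounds shown here alone, the full size of the step stays open since the value of compound 1 is a limit: the limit of > 40000 nM in this assay, at which 2 of the 4 values shown sit. Also open, going by these compounds, is what an amine, a carboxylic acid or a longer chain would give on this aromatic carbon.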